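Compound 4: 4-fluorobenzyl in place of 3,5-difluorobenzyl

The compounds below may be only part of what the source reports. "The series", "measured", "known", "first", "only" and "open" are said of these compounds alone.

In an ADME assay on Vero cells (Chlorocebus sabaeus) for cytotoxicity, read by MTT assay, with a stated time of 72 h (on this read-out higher numbers stand for lower toxicity in this test and lower numbers for higher toxicity in this test), compound 2 (`CCc1nc2ccc(Cl)cn2c1C(=O)NCc1ccc2c(c1)CCN(Cc1cc(F)cc(F)c1)C2`) gives 14 ug/mL as its reading and stands lowest of the three numbers at hand. Compound 1 (`CCc1nc2cc(Cl)ccn2c1C(=O)NCc1ccc2c(c1)CCN(Cc1ccc(OC)cc1)C2`) gives 32 ug/mL and compound 3 (`CCc1nc2cc(Cl)ccn2c1C(=O)NCc1ccc2c(c1)CCN(Cc1cc(F)cc(F)c1)C2`) gives 48 ug/mL as their readings, and both lie higher than compound 2 by more than the scatter.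

Compound 4 (`CCc1nc2ccc(Cl)cn2c1C(=O)NCc1ccc2c(c1)CCN(Cc1ccc(F)cc1)C2`) has 4-fluorophenyl in place of 3,5-difluorophenyl on a saturated chain carbon bound to an amine nitrogen in a ring. Within the data shown here, the only measured change at that place is a 1.5-fold higher number from compound 1 to compound 3 (0.18 log units; within the scatter) and it involves 3,5-difluorophenyl too. That step stays within the scatter, although it was seen on the core of compound 3, which differs from the core of compound 2. No step beyond the scatter is therefore expected in this assay for this change. The expected size is a 1.1-fold higher number from compound 2 to compound 4 (0.06 log units; within the scatter) and it remains an estimate. For compound 4 the estimated value is 16 ug/mL with an expected range from 7 ug/mL to 34 ug/mL for the reading.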

Compound 4, half-maximal cytotoxic concentration: > 64 ug/mL
Compound 4 was reported as a limit (the forecaster's own chance of this, stated with the estimate: 3%); middle value at least 4.0-fold (0.60 log units) away from the limit.
By their numbers in this assay, from the lowest: compound 2; then compounds 1 and 3 (each within the scatter of the next). At a limit, above all of these: compound 4.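

In this assay, 4-fluorophenyl in place of 3,5-difluorophenyl on a saturated chain carbon bound to an amine nitrogen in a ring gives an at least 4.5-fold higher number from compound 2 to compound 4 (0.66 log units; beyond the scatter), so on the core of compound 2 the group at this place does change the reading. Among these compounds, the only earlier step at this place, a 1.5-fold higher number from compound 1 to compound 3 (0.18 log units; within the scatter), stayed within the scatter and was seen on another core, so it gave no sign of a change of this size. The reading of compound 4, > 64 ug/mL, is a limit of the assay and not a number: the limit of > 64 ug/mL in this assay, at which 1 of the 4 values shown sits.

On these data alone, how far the true value of compound 4 lies past that limit stays open, as does whether the same change would act alike on the core of compound 3. The compounds shown also leave open how a plain phenyl, an amine or a longer chain would read at this place.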